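This account rests on a few compounds, and the source may have more. Where it says the series, first, only, none or still open, it means among the compounds named here.

Compound 1 `CCCOc1ccc(C(=O)Nc2cccc(Nc3ccc(F)cc3)n2)cc1` in an in vitro assay on HEK-tsA201 cells for antagonist activity at Neuronal acetylcholine receptor; alpha3/beta4 (Homo sapiens), read by fluorescence and calcium flux; on this read-out higher numbers stand for weaker inhibition and lower numbers for stronger inhibition: > 100000 nM, which is a limit of the assay and not a number. Compound 2 `CCCOc1ccc(C(=O)Nc2cccc(Nc3ccc(OC)cc3)n2)cc1` in this assay: > 100000 nM, likewise a limit of the assay.

Compound 2 thus stands at a limit in this assay rather than at a measured number. Going by the values given here, the single step among the measured compounds, a step that the two limits leave unreadable from compound 1 to compound 2, cannot be read because of the limit of > 100000 nM in this assay, at which 2 of the 2 values shown sit. Compound 3 `CCCOc1ccc(C(=O)Nc2cccc(N3CCCCC3)n2)cc1` has not yet been measured in this assay. It differs from compound 2 in one place: piperidin-1-yl in place of (4-methoxyphenyl)amino on an aromatic carbon. Among the compounds with values here, no measured step bears on this change, and the one step that was measured has no readable size, so it offers no guide to direction or magnitude. Within the data shown here, the two measured values show only that the shared core, with either of the two groups so far examined, does not inhibit within the range of the assay. Compound 3 is therefore expected to give a result of the same kind, with a fair chance that this assay again reports only a limit. Its estimated value is 100000 nM, expected to lie between 10000 nM and 300000 nM. The step of a number no higher from compound 2 to compound 3 (the limit leaves the size open) is expected to be none beyond the scatter.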

Compound 3, half-maximal inhibitory concentration: > 100000 nM
Compound 3: only a limit was reported; the forecaster's own chance of this, stated with the estimate: 80%; the middle value lies on the limit itself.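

The steps from compound 1 and from compound 2 to compound 3 cannot be read, because all three results are a limit of the assay and not numbers: the limit of > 100000 nM in this assay, at which 3 of the 3 values shown sit. The compounds shown leave open how strongly, if at all, compound 1, compound 2 and compound 3 inhibit in this assay, and whether their differing groups change that inhibition.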